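From Isopropyl to Pentyl Ester: An Expected Growth Inhibition

The compounds below may be only part of what the source reports. "The series", "measured", "known", "first", "only" and "open" are said of these compounds alone.

Of the compounds shown here, three sharing one core have been tested in a functional assay on the whole organism for inhibition, with Lepidium sativum as the target, tested at 1 ppm; a higher number here means more inhibition of growth at the concentration tested, a lower number less inhibition of growth. Compound 1 `CCCC(C)ON1C(=O)c2ccccc2C1=O` gives 0%, and compound 2 `CCCCCCC(ON1C(=O)c2ccccc2C1=O)C(=O)OCC` gives 0%. Compound 3 `CC(C)OC(=O)C(C)ON1C(=O)c2ccccc2C1=O` gives 51%, the highest of the three, with compound 1 and compound 2 both well behind it. Among the measured compounds shown here, the only measured step, a number 51 percentage points higher from compound 1 to compound 3 (beyond the scatter), shows that an ester in that position matters greatly, but says nothing about the length of the ester chain. Compound 4 `CCCCCOC(=O)C(C)ON1C(=O)c2ccccc2C1=O` differs from compound 3 by pentyl in place of isopropyl on an oxygen next to a carbonyl group. For the measured compounds named here, no measured step bears directly on this change, so the expectation is loose and leans toward a modest loss. Compound 4 is expected to give 30%, within 0% to 60%. The estimated step is a number 21 percentage points lower from compound 3 to compound 4 (beyond the scatter).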

Compound 4, percent growth inhibition at one concentration: 64%
Compound 4: middle estimate off by 34 percentage points, on the low side, outside the stated range (above it).
By their numbers in this assay, from the lowest: compounds 1 and 2 (each within the scatter of the next); then compound 3; then compound 4.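

Pentyl in place of isopropyl on an oxygen next to a carbonyl group goes with a number 13 percentage points higher from compound 3 to compound 4 (beyond the scatter). The presence of the ester is therefore not the whole story: the group on its oxygen also matters, and here the change to pentyl does not cost inhibition. No available measurement gives a reason for this step. This single step cannot separate the effect of chain length from that of losing the branch. Going by these compounds, whether a longer chain such as octyl would raise the value further, or a free carboxylic acid would keep any of it, remains open.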